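3,4-Difluorophenyl in Place of 1,3-Benzothiazol-2-yl

This account rests on a few compounds, and the source may have more. Where it says the series, first, only, none or still open, it means among the compounds named here.

Three compounds share one core. In an assay on THP-1 cells for displacement of a labelled ligand from C-C chemokine receptor type 1 (Homo sapiens) (on this read-out higher numbers stand for weaker inhibition and lower numbers for stronger inhibition), compound 1 `CC(C)C(NC(=O)c1ccccc1)C(=O)N1CCC(c2ccc(F)cc2)CC1` gives 423 nM. Compound 2 `CC(C)[C@@H](NC(=O)c1nc2ccccc2s1)C(=O)N1CCC(c2ccc(Cl)cc2)CC1` gives 18 nM in this assay, the lowest of the three numbers. Compound 3 `CC[C@@H](C)[C@@H](NC(=O)c1ccccc1)C(=O)N1CCC(c2ccc(Cl)cc2)CC1` gives 45 nM, the nearest to compound 2, while compound 1 lies furthest away.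

Compound 4 `CC(C)[C@@H](NC(=O)c1ccc(F)c(F)c1)C(=O)N1CCC(c2ccc(Cl)cc2)CC1` has not yet been measured. It differs from compound 2 in one place: 3,4-difluorophenyl in place of 1,3-benzothiazol-2-yl on a carbonyl carbon

Going by the values given here, no measured pair shows this exact change. Still, compound 3, which carries an unsubstituted phenyl on the same carbonyl, sits at 45 nM, above compound 2. The expected step for compound 4 is therefore a modest rise, a 2.8-fold higher number from compound 2 to compound 4 (0.44 log units; beyond the scatter), beyond the scatter. Compound 4 is estimated at 50 nM, within 20 nM to 150 nM.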

Compound 4, half-maximal inhibitory concentration: 14 nM
Compound 4: the middle estimate sits 3.6-fold (0.55 log units) above what was measured; measured number outside the range, below it.
By their numbers in this assay, from the lowest: compounds 4 and 2 (each within the scatter of the next); then compound 3; then compound 1.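

In this assay, placing 3,4-difluorophenyl instead of 1,3-benzothiazol-2-yl on the carbonyl carbon leaves the two compounds indistinguishable (a 1.3-fold lower number from compound 2 to compound 4 (0.11 log units; within the scatter)). In this pair, the position therefore does not need the five-membered aromatic ring with its nitrogen and sulfur, nor the hydrogen-bond acceptors counted in that group. No measurement available here explains why the two groups match.

Going by these compounds, it remains open how a carboxylic acid or an amine on the phenyl ring would fare in this position, and whether a single fluorine would match the two.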